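The source may hold more compounds than are shown below. What is called first, only, known or untested is meant among the compounds shown, and "the series" means these compounds.

Compound 1 `Cn1c(Cc2nn(C)c(=O)c3ccccc23)nnc1SCCCCCCCC(=O)Nc1ccc(Cl)cc1Cl`: 2200 nM
Compound 2 `CCOC(CCn1c(Cc2nn(C)c(=O)c3ccccc23)nnc1SCC(=O)Nc1ccc(Cl)cc1Cl)OCC`: > 30000 nM
Compound 3 `Cn1nc(Cc2nnc(SCC(=O)Nc3ccc(Cl)cc3Cl)n2CCC=O)c2ccccc2c1=O`: 6000 nM

In an assay on 32D cells for inhibition of interleukin-15 (Mus musculus), read by resazurin assay, with stated times of 30 min and 2.5 days, in the presence of a further agent that is not named here (a lower number here means a stronger inhibitor, a higher number a weaker inhibitor), compound 1 gives 2200 nM, the lowest of the two numbers shown; compound 3 gives 6000 nM. Compound 2 reaches only the limit of the assay, > 30000 nM, which is the limit of > 30000 nM in this assay, at which 1 of the 3 values shown sits. Within the data shown here, the one measured step is an at least 5.0-fold lower number from compound 2 to compound 3 (0.69 log units; beyond the scatter). Compound 4 `Cn1nc(Cc2nnc(SCCCCCCCC(=O)Nc3ccc(Cl)cc3Cl)n2CCC=O)c2ccccc2c1=O` differs from compound 1 by formylmethyl in place of hydrogen on a saturated chain carbon bound to an aromatic nitrogen, so compound 4 pairs the long chain of compound 1 with the formyl-bearing side chain of compound 3. No measured pair compares that side chain with hydrogen or methyl; the step shown concerns formyl against diethoxymethyl only and does not set the size here. The expected step in this assay is therefore a 1.1-fold higher number from compound 1 to compound 4 (0.06 log units; within the scatter), none beyond the scatter. Compound 4 is estimated at 2500 nM, within 800 nM to 8000 nM.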

Compound 4, half-maximal inhibitory concentration: 2500 nM
Compound 4: middle estimate and measured number agree at the digits printed, within the range that was stated.
By their numbers in this assay, from the lowest: compounds 1 and 4 (each within the scatter of the next); then compound 3. At a limit, above all of these: compound 2.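

In this assay the change reads as a 1.1-fold higher number from compound 1 to compound 4 (0.06 log units; within the scatter), so formylmethyl in place of hydrogen on a saturated chain carbon bound to an aromatic nitrogen leaves the number within the scatter. Among these compounds, the earlier compounds compared formyl only with diethoxymethyl; this pair is the first to set the formyl-bearing side chain against the methyl of compound 1. No available evidence bears on this step.

Open, going by these compounds, is whether an amine or a carboxylic acid in place of the formyl would hold the number of compound 4. Also open, on these data alone, is how a longer chain ending in formyl would read at this position.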